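Styryl Lactam Series: Trifluoromethyl Step from Compound 2

This account rests on a few compounds, and the source may have more. Where it says the series, first, only, none or still open, it means among the compounds named here.

compound 1 `COc1ccc(/C=C/C2CC(=O)C=CO2)cc1`: 156 uM
compound 2 `O=C1C=CCC(/C=C/c2ccccc2)N1`: 607 uM

In a functional assay on MCF7 cells (Homo sapiens) for inhibition, read by sulforhodamine B assay, with a stated time of 48 h (a higher number here means a weaker inhibitor of growth, a lower number a stronger inhibitor of growth), compound 1 gives 156 uM and compound 2 gives 607 uM. Compound 2 holds the higher of the two numbers, and the gap to compound 1 is beyond the scatter. Compound 3 `O=C1C=CCC(/C=C/c2ccccc2C(F)(F)F)N1` differs from compound 2 by trifluoromethyl in place of hydrogen on an aromatic carbon. For the measured compounds named here, no measured pair shows this change, so there is no basis for a large shift; the step from compound 2 to compound 3 is expected to be a 1.5-fold lower number from compound 2 to compound 3 (0.18 log units; within the scatter), not clearly beyond the scatter. Compound 3 is estimated at 400 uM, with a range from 150 uM to 1000 uM.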

Compound 3, concentration for growth inhibition (reported as GI): 120 uM
Compound 3: middle estimate off by 3.3-fold (0.52 log units), on the high side; measured number outside the range, below it.
By their numbers in this assay, from the lowest: compounds 3 and 1 (each within the scatter of the next); then compound 2.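

In this assay, for the compounds shown here, trifluoromethyl in place of hydrogen on an aromatic carbon, ortho to a group of 9 heavy atoms, gives a 5.1-fold lower number from compound 2 to compound 3 (0.70 log units; beyond the scatter), the first measured step. This position therefore accepts the group, and the change moves growth inhibition beyond the scatter in the stronger direction. No available measurement accounts for the step.

From the compounds shown here alone, whether an amine or a carboxylic acid at this position would give a similar step remains open. So does whether trifluoromethyl elsewhere on the aromatic ring, or on the core of compound 1, would do the same.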